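The compounds below may be only part of what the source reports. "The series", "measured", "known", "first", "only" and "open" are said of these compounds alone.

Three compounds of one series were set up for testing in a functional assay on aorta (Rattus norvegicus) for inhibition; on this read-out lower numbers stand for stronger inhibition and higher numbers for weaker inhibition. Compound 1 `CC(C)c1cccc(C2CNCC2C(=O)Nc2cc3cc[nH]c(=O)c3cc2Cl)c1` and compound 2 `CCc1cccc(C2CNCC2C(=O)Nc2cc3cc[nH]c(=O)c3cc2Cl)c1` carry isopropyl and ethyl groups on the phenyl ring, but no number was obtained for either: in this assay compound 1 reads "not determined" (no result reported), and in this assay compound 2 reads "not determined" (no result reported). Within the data shown here, compound 3 `O=C(Nc1cc2cc[nH]c(=O)c2cc1Cl)C1CNCC1c1ccccc1` is the only member with a number in hand: in this assay compound 3 gives 89 nM, which makes it the sole reference point, with nothing to rank it against.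

Compound 4 `O=C(Nc1cc2cc[nH]c(=O)c2cc1Cl)C1CNCC1c1cccc(Br)c1` differs from compound 3 in a single place: bromo in place of hydrogen on an aromatic carbon, sitting on an aromatic carbon of a six-membered aromatic ring of carbon only, meta to a large group. Among the measured compounds shown here, with no measured pair that shows what such a swap does, the step in this assay from compound 3 to compound 4 can only be guessed; a small shift, either toward stronger inhibition or none beyond the usual scatter, seems most plausible, and a large change in either direction less so.

On that basis compound 4 is expected to give about 60 nM in this assay, with a likely span from 15 nM to 250 nM, meaning an estimated step of a 1.5-fold lower number from compound 3 to compound 4 (0.17 log units; within the scatter).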

Compound 4, half-maximal inhibitory concentration: 63 nM
Compound 4: the middle estimate sits 1.1-fold (0.02 log units) below what was measured, within the range that was stated.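

In this assay, the swap of phenyl to 3-bromophenyl gives a 1.4-fold lower number from compound 3 to compound 4 (0.15 log units; within the scatter), so this change cannot be told apart from the ordinary variation between repeated measurements. Among these compounds, this is the first measured change on this ring, and it shows that one bromo in place of hydrogen, on this aromatic carbon meta to a large group, leaves inhibition where it was, within the scatter, with both compounds still reading in the same range. No independent measurement is available to say why the number holds steady.

From the compounds shown here alone, the steps to compound 1 and compound 2 cannot be read, so it stays open whether the isopropyl and ethyl groups on this ring would fit the same picture as bromo. Also open, going by these compounds, is how an amine, a carboxylic acid or a methoxy group at this place would read in this assay, and whether bromo on a different carbon of the ring would leave the number just as unchanged.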